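The compounds below may be only part of what the source reports. "The series", "measured", "known", "first", "only" and "open" are said of these compounds alone.

Measured compounds:
compound 1 `CC(=O)c1ccc(OCCCCC#N)cc1O` – 0%
compound 2 `CCc1cc(C(C)=O)c(O)cc1OCCCCC#N` – 57%
compound 3 `COCc1cc(C(C)=O)c(O)cc1OCCCCCCC#N` – 7%

In an assay on isolated protein for binding affinity to leukotriene B4 receptor 1 (Homo sapiens), tested at 1 uM (on this read-out lower numbers stand for less inhibition and higher numbers for more inhibition at the one concentration tested (going by the name of the read-out)), compound 2 stands highest of the three, with compound 3 nearest and compound 1 furthest. Going by the values given here, the only measured step that touches this position is a number 57 percentage points higher from compound 1 to compound 2 (beyond the scatter). Compound 4 `CC(=O)c1cc(C=O)c(OCCCCC#N)cc1O` carries the change (formyl in place of ethyl on an aromatic carbon). Among the compounds with values here, no measured pair shows formyl at this place, and compound 3 differs from compound 2 in two places at once, so it only shows that a different group here goes with a low number. Since ethyl alone accounts for the whole rise in a number 57 percentage points higher from compound 1 to compound 2 (beyond the scatter), replacing it is expected to cost most of that gain: a step of a number 39 percentage points lower from compound 2 to compound 4 (beyond the scatter) is estimated. Compound 4 is thus expected at 18%, likely between 0% and 45%.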

Compound 4, a percentage reported as inhibition, at one concentration (the size of the read-out at that concentration, not a potency): 3%
The estimate for compound 4 lay 15 percentage points above the measured number; measured number inside the range.
By their numbers in this assay, from the lowest: compounds 1, 4 and 3 (each within the scatter of the next); then compound 2.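

In this assay, a number 54 percentage points lower from compound 2 to compound 4 (beyond the scatter) shows that this position does not treat ethyl and formyl alike, although the two groups have the same heavy-atom count and formyl adds a hydrogen-bond acceptor. With a number 3 percentage points higher from compound 1 to compound 4 (within the scatter), formyl keeps none of the gain that ethyl gives over hydrogen at this place.

The compounds shown leave open how methyl, propyl or an amine at this place would read, and so whether the gain is particular to ethyl. Nothing available explains the gap between ethyl and formyl.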